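Swapping Amino for Methoxy: What the Cell Assay Suggests

The compounds below may be only part of what the source reports. "The series", "measured", "known", "first", "only" and "open" are said of these compounds alone.

The three measured compounds were all tested in a functional assay on BT-549 cells (Homo sapiens) for cytotoxicity, read by sulforhodamine B assay, with a stated time of 48 h, tested at 10 uM; a higher number here means a weaker effect of the compound at the concentration tested, a lower number a stronger effect:

compound 1, `COc1cc(-c2cc(/C=C/C(=O)c3ccc(N)cc3)[nH]n2)cc(OC)c1OC`: -89%
compound 2, `COc1ccc(-c2cc(/C=C/C(=O)c3ccc(N)cc3)[nH]n2)cc1OC`: -91%
compound 3, `COc1ccc(-c2cc(/C=C/C(=O)c3cc(OC)c(OC)c(OC)c3)[nH]n2)cc1OC`: -80%

Compound 1 stands second highest of these three numbers. Its nearest neighbour is compound 2, and the step of a number 2 percentage points lower from compound 1 to compound 2 (within the scatter) lies within the scatter, so the two values show no real difference. Compound 3 gives a somewhat higher number, yet that gap too falls within the scatter, so none of the three can be called stronger or weaker than the others.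

Compound 4, `COc1ccc(C(=O)/C=C/c2cc(-c3cc(OC)c(OC)c(OC)c3)n[nH]2)cc1`, differs from compound 1 in one place: methoxy in place of amino on an aromatic carbon. Going by the values given here, no measured pair swaps exactly these two groups. Among the compounds with values here, the only measured step, a number 2 percentage points lower from compound 1 to compound 2 (within the scatter), removes a methoxy from the other aromatic ring and changes nothing beyond the scatter. Compound 3, which carries no amino group, gives -80%, a number close to compound 1. Taken together, the change from compound 1 to compound 4 is expected to give a step of a number 17 percentage points higher from compound 1 to compound 4 (beyond the scatter), most likely small and toward a weaker effect. The value expected for compound 4 is -72%, within a range from -95% to -35%.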

Compound 4, a percentage reported as activity, at one concentration (the size of the read-out at that concentration, not a potency): -65%
The estimate for compound 4 lay 7 percentage points below the measured number; low and high end bracket the measured number.
By their numbers in this assay, from the lowest: compounds 2, 1 and 3 (each within the scatter of the next, the first and the last beyond it); then compound 4.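

In this assay, the change from 4-aminophenyl to 4-methoxyphenyl is the first one-place change among these compounds to move the number beyond the usual scatter, with a step of a number 24 percentage points higher from compound 1 to compound 4 (beyond the scatter), and the effect of compound 4 at the concentration tested is the weaker one. Going by these compounds alone, the only earlier one-place step, a number 2 percentage points lower from compound 1 to compound 2 (within the scatter), concerned the other aromatic ring, so it said nothing about this site. Within the data shown here, this result therefore gives the first sign that the group on this aromatic carbon, para to a large group, can change the read-out, although the step remains modest.

With only amino and methoxy shown at this position, it remains open whether a hydroxyl group, a dimethylamino group or a plain hydrogen would behave more like amino or more like methoxy. From the compounds shown here alone, it is also open whether the same swap would give a step of similar size starting from compound 2, which carries the same amino group but has one methoxy fewer on its other ring.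

No measurement shown here bears on why this swap weakens the effect.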